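Oxazole for methylimidazole on the chain carbon of compound 3

The compounds below may be only part of what the source reports. "The series", "measured", "known", "first", "only" and "open" are said of these compounds alone.

Going by the values given here, compound 3 `Cc1nc(-c2ccc(C(F)(F)F)cc2)sc1COc1ccc([C@H](CC(=O)O)c2nccn2C)cc1` gives 73 nM in an assay on CHO cells for agonist activity at Free fatty acid receptor 1 (Homo sapiens), read by calcium flux (on this read-out higher numbers stand for an effect only at larger amounts of compound and lower numbers for an effect already at smaller amounts), the highest of the three numbers measured so far; compound 1 `Cc1cc(Cl)ccc1-c1cccc(COc2ccc([C@H](CC(=O)O)c3nccn3C)cc2)c1` gives 33 nM and compound 2 `Cc1cc(Cl)ccc1-c1cccc(COc2ccc([C@H](CC(=O)O)c3ncnn3C)cc2)c1` gives 33 nM, each beyond the scatter from compound 3. Compound 4 `Cc1nc(-c2ccc(C(F)(F)F)cc2)sc1COc1ccc([C@H](CC(=O)O)c2cnco2)cc1` differs from compound 3 by 1,3-oxazol-5-yl in place of 1-methyl-1H-imidazol-2-yl on a saturated chain carbon bound to an aromatic carbon and a saturated chain carbon. Among the compounds with values here, the one measured step at this position is no change at the digits printed from compound 1 to compound 2 (within the scatter), a heteroaryl-for-heteroaryl exchange on a different core that left the number unchanged. Within the data shown here, the exchange to 1,3-oxazol-5-yl is of the same kind, but no measured pair covers this group, so no shift beyond the scatter is expected, with the number of compound 3 as the anchor. Compound 4 is therefore expected at 90 nM in this assay, in a range from 30 nM to 270 nM. Among the measured compounds shown here, the expected step of a 1.2-fold higher number from compound 3 to compound 4 (0.09 log units; within the scatter) is estimated to stay within the scatter, with a wide range because the only comparable step, no change at the digits printed from compound 1 to compound 2 (within the scatter), comes from a different core.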

Compound 4, half-maximal effective concentration: 57 nM
Estimate against measurement, compound 4: 1.6-fold (0.20 log units) above, and the stated range covers the measured number.
By their numbers in this assay, from the lowest: compounds 1, 2, 4 and 3 (each within the scatter of the next, the first and the last beyond it).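

In this assay the exchange reads a 1.3-fold lower number from compound 3 to compound 4 (0.11 log units; within the scatter) and so extends the picture at the saturated chain carbon to the core of compound 3. The earlier step, no change at the digits printed from compound 1 to compound 2 (within the scatter) on the core of compound 1, is also within the scatter, so both heteroaryl exchanges at this place on the two cores stay within it. The entering 1,3-oxazol-5-yl has one heavy atom fewer than 1-methyl-1H-imidazol-2-yl and brings an oxygen, and the number still does not move beyond the scatter, though no measurement here bears on the reason.

On these data alone, whether a group that is not a five-membered aromatic ring, such as a dimethylamino group or a plain methyl, would hold the number at this place remains open. Also open, as far as these compounds go, is how 1,3-oxazol-5-yl reads on the core of compound 1.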